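Swapping a Group on a Carbonyl Carbon

The source may report more compounds than this note shows. Statements on the series, on what has been measured and on what is new or still open speak of the compounds shown alone.

Among the compounds with values here, in a functional assay on A2780 cells (Homo sapiens) for antiproliferative activity (on this read-out higher numbers stand for weaker inhibition and lower numbers for stronger inhibition), this small family has only one number so far: compound 1 `Cc1ccc2c(c1C)CN(CCCN)CC2c1ccccc1` gives 2420 nM. Compound 2 `Cc1ccc2c(c1C)CN(C(N)=O)CC2c1ccccc1` shares the core of compound 1, but the entry for compound 2 reads "not determined" (no result reported). It therefore has no place on the scale and offers no starting point for comparison.

Compound 3 `Cc1ccc2c(c1C)CN(C(=O)N(C)CCCN(C)C)CC2c1ccccc1` differs from compound 2 by one change on a carbonyl carbon: (3-(dimethylamino)propyl)(methyl)amino in place of amino on a carbonyl carbon. Here (3-(dimethylamino)propyl)(methyl)amino stands in place of amino, a much larger group replacing a very small one.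

With no number for compound 2, the size of this step in this assay cannot be worked out, and no direction can be assigned to it. Within the data shown here, the only anchor is compound 1 at 2420 nM, so the expectation is that the new compound will fall in the same general region, with no clear shift beyond the scatter. One measured neighbour is thin evidence, so the range is kept wide. Compound 3 is expected at about 2500 nM, with an estimated range of 600 nM to 10000 nM.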

Compound 3, half-maximal inhibitory concentration: 1210 nM
Beside the measured number, compound 3's estimate is 2.1-fold (0.32 log units) above it, and the stated range covers the measured number.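

In this assay, within the data shown here, compound 3 gives 1210 nM but compound 2 has no number on this scale, so no step between compound 2 and compound 3 can be read. No other data shown here help to explain the value of compound 3. The compounds shown leave open how swapping the group on the carbonyl carbon changes antiproliferative activity.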